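Shortening the chain on the diene carbon of compound 1

The source may report more compounds than this note shows. Statements on the series, on what has been measured and on what is new or still open speak of the compounds shown alone.

Compound 1 `CCCCCCCC/C(=C\C=C\C(=O)N[C@H](C)CCCc1cccnc1)c1ccc(OC)cc1` is the reference point of this pair. In a functional assay with platelet-activating factor receptor (Cavia porcellus) as the target (a lower number here means that less compound is needed, a higher number that more compound is needed for the effect), compound 1 gives 0.1 mg/kg, the lowest of the two numbers in hand. Compound 2 `O=C(C=C(c1ccccc1)c1ccccc1)NCCCCc1cccnc1` is the nearest comparison; in this assay compound 2 gives 0.58 mg/kg, a higher number that lies beyond the usual scatter. Going by the values given here, no pair of measured compounds differs in a single place, so no direct single-change step is available from which to read the weight of a change.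

The next compound, compound 3 `COc1ccc(/C(=C/C=C/C(=O)N[C@H](C)CCCc2cccnc2)C(C)C)cc1`, keeps the core of compound 1 and differs from it in one place: isopropyl in place of octyl on a double-bonded chain carbon bound to an aromatic carbon and a double-bonded chain carbon. Among the compounds with values here, with no measured single step to lean on, the expectation rests on the two values alone, and a moderate rise in dose is expected, with a step from compound 1 to compound 3 of about a 3.0-fold higher number from compound 1 to compound 3 (0.48 log units; beyond the scatter) in this assay. For compound 3 in this assay the estimated value is 0.3 mg/kg, expected to lie between 0.08 mg/kg and 1.2 mg/kg.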

Compound 3, dose for 50% inhibition: 0.41 mg/kg
Estimate against measurement, compound 3: 1.4-fold (0.14 log units) below; measured number inside the range.
By their numbers in this assay, from the lowest: compound 1; then compounds 3 and 2 (each within the scatter of the next).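

Going by these compounds alone, replacing octyl with isopropyl on a double-bonded chain carbon bound to an aromatic carbon and a double-bonded chain carbon gives a 4.1-fold higher number from compound 1 to compound 3 (0.61 log units; beyond the scatter) in this assay, the first single-place step and a sign that the group at this position affects the dose needed. Both groups are carbon-only and without a ring, and the count under the change falls from 8 heavy atoms to 3, yet the effect remains measurable, with compound 3 at 0.41 mg/kg. No measurement in hand accounts for the size or direction of this step, so its cause remains unassigned.

With only octyl and isopropyl compared at this position, the change in chain length cannot be separated from the change to a branched group, and a straight propyl or butyl chain would be needed to tell these apart. Also open, as far as these compounds go, is how this position responds to a chain ending in an amine or a carboxylic acid, and whether the step carries over to compounds with a different core.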